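Stripping the benzyl ring in a bis(trifluoromethyl) sulfonamide series

The source may report more compounds than this note shows. Statements on the series, on what has been measured and on what is new or still open speak of the compounds shown alone.

Compound 1 `O=S(=O)(NCCCCNCc1ccc(Br)cc1)c1cc(C(F)(F)F)cc(C(F)(F)F)c1`: 3200 nM
Compound 2 `O=S(=O)(NCCCNCc1ccc(Cl)cc1)c1cc(C(F)(F)F)cc(C(F)(F)F)c1`: 2300 nM
Compound 3 `O=S(=O)(NCCCNCc1ccc(Cl)c(C(F)(F)F)c1)c1cc(C(F)(F)F)cc(C(F)(F)F)c1`: 7900 nM

Three compounds share a sulfonamide core bearing two trifluoromethyl groups and differ at the benzyl end of the chain. In a toxicity assay on MCF-10A cells (Homo sapiens) for inhibition, read by MTT assay, with a stated time of 72 h (on this read-out lower numbers stand for stronger inhibition of growth and higher numbers for weaker inhibition of growth), compound 3 gives the highest number of the three, so it holds back growth the least; compound 1 with 3200 nM and compound 2 with 2300 nM both sit lower by more than the scatter.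

Compound 4 `O=S(=O)(NCCCNCc1ccccc1)c1cc(C(F)(F)F)cc(C(F)(F)F)c1` has not yet been measured. It differs from compound 3 in one place: phenyl in place of 4-chloro-3-(trifluoromethyl)phenyl on a saturated chain carbon bound to an amine nitrogen. Among the measured compounds shown here, one measured step bears directly on this: a 3.4-fold higher number from compound 2 to compound 3 (0.54 log units; beyond the scatter), a modest rise when trifluoromethyl entered. Taking it out again is expected to reverse that. For the measured compounds named here, removing the chlorine has no measured counterpart; a 1.4-fold lower number from compound 1 to compound 2 (0.14 log units; within the scatter) only swapped one halogen for another alongside a chain change. Compound 4 is therefore expected to give 3000 nM, within 1200 nM to 8000 nM, an estimated step of a 2.6-fold lower number from compound 3 to compound 4 (0.42 log units; beyond the scatter).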

Compound 4, concentration for 50% growth inhibition: 13000 nM
The estimate for compound 4 lay 4.3-fold (0.64 log units) below the measured number, and the stated range ends below it.
By their numbers in this assay, from the lowest: compounds 2 and 1 (each within the scatter of the next); then compounds 3 and 4 (each within the scatter of the next).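

The chlorine matters more here than the step from compound 3 suggests: in this assay, hydrogen in place of chloro on an aromatic carbon weakens growth inhibition (a 5.7-fold higher number from compound 2 to compound 4 (0.75 log units; beyond the scatter)). The comparison with the bromo compound points the same way, although benzylamino in place of ((4-bromobenzyl)amino)methyl also alters the chain (a 4.1-fold higher number from compound 1 to compound 4 (0.61 log units; beyond the scatter)). Replacing 4-chloro-3-(trifluoromethyl)phenyl with phenyl produces no clear change (a 1.6-fold higher number from compound 3 to compound 4 (0.22 log units; within the scatter)), so removing chlorine did not reverse the rise seen when trifluoromethyl entered; adding trifluoromethyl to compound 2 and removing its chlorine both raise the number.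

As far as these compounds go, whether fluoro, methoxy or a nitrile in place of chloro on that aromatic carbon would keep the number down remains open. Nothing available explains why these changes shift the number as they do.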